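The source may report more compounds than this note shows. Statements on the series, on what has been measured and on what is new or still open speak of the compounds shown alone.

Working notes on the series. Compound 1 `COc1ccc(/C=C\c2cc(OC)c(OC)c(OC)c2)cc1OCc1ccc(CNC(C)(C)C(=O)O)cc1` is the reference point in an ADME assay on NCM460 cells (Homo sapiens) for cytotoxicity, read by CCK-8 assay, with a stated time of 48 h; a lower number here means a stronger inhibitor, a higher number a weaker inhibitor. In this assay compound 1 gives only a limit, > 50000 nM. Compound 2 `COc1ccc(/C=C\c2cc(OC)c(OC)c(OC)c2)cc1OCc1ccc(C=O)cc1` carries a formyl in place of ((1-carboxy-1-methylethyl)amino)methyl on an aromatic carbon, and in this assay compound 2 gives 41000 nM. For the measured compounds named here, the step of an at least 1.2-fold lower number from compound 1 to compound 2 (0.08 log units; that floor lies within the scatter) is the only measured step, and it does not separate compound 1 from compound 2; where compound 1 stands is set by the limit of > 50000 nM in this assay, at which 1 of the 2 values shown sits.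

Compound 3 `COc1ccc(/C=C\c2cc(OC)c(OC)c(OC)c2)cc1OCc1ccc(CNCCN(C)C)cc1` is the next member. It differs from compound 1 in one place: 2-(dimethylamino)ethyl in place of 1-carboxy-1-methylethyl on an amine nitrogen. The 1-carboxy-1-methylethyl group leaves the amine nitrogen and 2-(dimethylamino)ethyl enters there, so the ((2-(dimethylamino)ethyl)amino)methyl substituent stays on the same aromatic carbon. Going by the values given here, the one measured step at this position, an at least 1.2-fold lower number from compound 1 to compound 2 (0.08 log units; that floor lies within the scatter), stayed within the scatter even when the whole substituent was replaced by formyl, so for this smaller exchange no step beyond the scatter is expected in this assay, and a limit remains quite possible. For compound 3 the expected step is an at least 1.1-fold lower number from compound 1 to compound 3 (0.04 log units; that floor lies within the scatter). The value expected for compound 3 in this assay is 45000 nM, within 15000 nM to 100000 nM.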

Compound 3, half-maximal inhibitory concentration: 35000 nM
Estimate against measurement, compound 3: 1.3-fold (0.11 log units) above; low and high end bracket the measured number.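

With 2-(dimethylamino)ethyl in place of 1-carboxy-1-methylethyl on the amine nitrogen, the series gains its first change at that nitrogen itself, and the result is an at least 1.4-fold lower number from compound 1 to compound 3 (0.15 log units; that floor lies within the scatter). Against the formyl member, ((2-(dimethylamino)ethyl)amino)methyl on the same aromatic carbon gives a 1.2-fold lower number from compound 2 to compound 3 (0.07 log units; within the scatter), so the two substituents are not told apart in this assay, and no step shown so far at this position lies beyond the scatter. The value of compound 1 is a limit, so its step gives only a floor and its full size cannot be read: the limit of > 50000 nM in this assay, at which 1 of the 3 values shown sits.

The compounds shown leave open whether any exchange at this position can move the number beyond the scatter in this assay, and they do not show whether the carboxylic acid or the terminal dimethylamino group matters on its own. A primary amine, a longer chain ending in dimethylamino, or a carboxylic acid on a plain ethyl chain at the amine nitrogen would each separate these parts of the substituent.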